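The source may hold more compounds than are shown below. What is called first, only, known or untested is meant among the compounds shown, and "the series" means these compounds.

In a functional assay on NCI-H460 cells (Homo sapiens) for antiproliferative activity, read by MTT assay, with a stated time of 48 h (on this read-out higher numbers stand for weaker inhibition and lower numbers for stronger inhibition), compound 1 (`COc1cc(-c2cccc3nc(-c4cccc(Cl)c4)oc23)cc(OC)c1OC`) reads > 25000 nM as a limit of the assay, not a number. Compound 2 (`COc1cc(-c2cccc3nc(-c4ccc(C)cc4)oc23)cc(OC)c1OC`) gives 1900 nM there. Compound 3 (`COc1cc(-c2cccc3nc(-c4cccc(O)c4)oc23)cc(OC)c1OC`) stands level with it at 1900 nM in this assay. Compound 4 (`COc1cc(-c2cccc3nc(-c4ccc5cc[nH]c5c4)oc23)cc(OC)c1OC`) carries 1H-indol-6-yl in place of 3-hydroxyphenyl on an aromatic carbon at the same place. Measured steps at this place diverge: no change at the digits printed from compound 2 to compound 3 (within the scatter) stays within the scatter, whereas an at least 13-fold lower number from compound 1 to compound 2 (1.11 log units; beyond the scatter) and an at least 13-fold lower number from compound 1 to compound 3 (1.11 log units; beyond the scatter) are both large. Those large steps both start from compound 1, so neither directly describes a change away from compound 3. A step of a 1.6-fold lower number from compound 3 to compound 4 (0.20 log units; within the scatter) is expected, none beyond the scatter. Compound 4 is estimated at 1200 nM in this assay, with 200 nM to 8000 nM as its expected range.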

Compound 4, half-maximal inhibitory concentration: 24 nM
The estimate for compound 4 lay 50-fold (1.70 log units) above the measured number; measured number below the stated range.
By their numbers in this assay, from the lowest: compound 4; then compounds 2 and 3 (each within the scatter of the next). At a limit, above all of these: compound 1.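

In this assay, 1H-indol-6-yl at this aromatic carbon gives a 79-fold lower number from compound 3 to compound 4 (1.90 log units; beyond the scatter) and a 79-fold lower number from compound 2 to compound 4 (1.90 log units; beyond the scatter), so this position can respond strongly even though 3-hydroxyphenyl and 4-methylphenyl could not be told apart there. Of the groups shown, only 1H-indol-6-yl takes the number clearly below the level shared by compounds 2 and 3. The step of an at least 1000-fold lower number from compound 1 to compound 4 (3.01 log units; beyond the scatter) rests on a limit, not a number: the limit of > 25000 nM in this assay, at which 1 of the 4 values shown sits.

The compounds shown leave open whether this drop needs the ring nitrogen of the indole or only the second ring. A naphthyl or a benzofuranyl group at this place would separate the two.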